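Chlorine Position Shift on the Amide Aryl Group

The compounds below may be only part of what the source reports. "The series", "measured", "known", "first", "only" and "open" are said of these compounds alone.

Measured in a functional assay on HT-1080 cells (Homo sapiens), read by transwell migration, with a stated time of 24 h, tested at 1 uM; a higher number here means a weaker effect of the compound at the concentration tested, a lower number a stronger effect:
compound 1 `CC(=O)OCc1ccc2oc(=O)c(C(=O)Nc3cccc(Cl)c3)cc2c1`: 66.9%
compound 2 `CC(=O)OCc1ccc2oc(=O)c(C(=O)N(C)c3cccc(Cl)c3)cc2c1`: 82.6%

Within the data shown here, compound 2 stands highest of the two numbers measured so far; its nearest neighbour is compound 1, and the gap between them is beyond the scatter. Among the measured compounds shown here, the only measured step in this assay is a number 15.7 percentage points higher from compound 1 to compound 2 (beyond the scatter), which concerns methyl in place of hydrogen on an amide-type nitrogen.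

Compound 3 `CC(=O)OCc1ccc2oc(=O)c(C(=O)N(C)c3ccc(Cl)cc3)cc2c1` is the next structure. It differs from compound 2 by 4-chlorophenyl in place of 3-chlorophenyl on an amide-type nitrogen. For the measured compounds named here, neither measured compound bears on where chlorine sits on the aryl ring, so no measured step speaks to this change; the methyl step is of a different kind. With nothing to indicate a shift, the expectation is no step beyond the scatter. For compound 3 the expected step is a number 2.6 percentage points lower from compound 2 to compound 3 (within the scatter). Compound 3 is therefore estimated at 80%, with a range from 62% to 96%.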

Compound 3, a percentage reported as activity, at one concentration (the size of the read-out at that concentration, not a potency): 98.6%
The estimate for compound 3 lay 18.6 percentage points below the measured number; measured number above the stated range.
By their numbers in this assay, from the lowest: compound 1; then compound 2; then compound 3.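

In this assay, 4-chlorophenyl in place of 3-chlorophenyl on the amide-type nitrogen gives a number 16 percentage points higher from compound 2 to compound 3 (beyond the scatter) even though the two compounds have the same atoms, so the arrangement of the aryl group alone moves the read-out beyond the scatter. Taken with the methyl on that nitrogen, the combined change gives a number 31.7 percentage points higher from compound 1 to compound 3 (beyond the scatter) and leaves compound 3 with the weakest effect of the three at the concentration tested. No measurement available here explains why the chlorine position matters.

Still open, on these data alone, is whether 4-chlorophenyl gives a similar step when the amide hydrogen is kept rather than replaced by methyl. Also open, as far as these compounds go, is how 2-chlorophenyl, or a methoxy group in place of the chlorine, would read at this position.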